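Compound 4 weighed against its measured neighbours

This account rests on a few compounds, and the source may have more. Where it says the series, first, only, none or still open, it means among the compounds named here.

Three compounds sharing one core have been run in an ADME assay on Huh-7 cells (Homo sapiens) for cytotoxicity; a higher number here means that more compound is tolerated, a lower number that less compound is tolerated. Compound 1 `Cc1ccccc1-c1nn(-c2ccc(Cl)cc2)cc1CNCCN1CCN(C)CC1` gives 17000 nM. Compound 2 `Cc1ccccc1-c1nn(-c2ccc(F)cc2)cc1CNCCN1CCN(C)CC1` reaches only the limit of the assay, > 20000 nM. Compound 3 `Cc1ccc(-c2nn(-c3ccc(F)cc3F)cc2CNCCN2CCN(C)CC2)cc1` likewise stops at the limit of the assay, > 20000 nM, so it stands on a range rather than a number. Two of the three values sit at the limit of > 20000 nM in this assay, at which 2 of the 3 values shown sit. Compound 4 `CN1CCN(CCNCc2cn(-c3ccc(F)cc3F)nc2-c2ccccc2Cl)CC1` differs from compound 3 by 2-chlorophenyl in place of 4-methylphenyl on an aromatic carbon. Within the data shown here, no measured step exchanges these two groups; the only measured step, an at least 1.1-fold higher number from compound 1 to compound 2 (0.07 log units; that floor lies within the scatter), lies within the scatter. No shift beyond the scatter is therefore expected in this assay, the expected step being a number no higher from compound 3 to compound 4 (the limit leaves the size open). Compound 4 is estimated at 20000 nM, with a range from 8000 nM to 45000 nM.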

Compound 4, half-maximal cytotoxic concentration: > 20000 nM
Compound 4: no number, only a limit; the forecaster's own chance of this, stated with the estimate: 55%; the middle value sits exactly at the limit.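

Compound 3 and compound 4 both stop at a limit rather than a number, so no step between them can be read in this assay: the limit of > 20000 nM in this assay, at which 3 of the 4 values shown sit.

The compounds shown leave open whether 2-chlorophenyl in place of 4-methylphenyl changes the tolerated concentration at all.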